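The compounds below may be only part of what the source reports. "The series", "measured", "known", "first", "only" and "open" are said of these compounds alone.

In a functional assay on HL-60 cells (Homo sapiens) for cytotoxicity, read by XTT assay, with a stated time of 72 h (a higher number here means a weaker inhibitor, a lower number a stronger inhibitor), compound 1 `CCCCCCCC/C=C\CCCCCCCCOc1cc(O)c(C(C)=O)c(O)c1` gives 32000 nM. Compound 2 `CCCCCCCC/C=C\CCCCCCCCOc1cc(O)cc(O)c1C(C)=O`, which carries the same unsaturated long chain on the shared core, gives 32000 nM, so the two stand level within the scatter of the measurement. Compound 3 `CC(=O)c1c(O)cc2c(c1O)CCC(C)(C)O2`, which has no such long chain, is reported as > 100000 nM, and this is a limit of the assay and not a number.

The account now turns to compound 4 `CCCCCCCCCCCCCCCCCCOc1cc(O)cc(O)c1C(C)=O`, which departs from compound 2 in one place: decyl in place of dec-1-en-1-yl on a saturated chain carbon, eight bonds along the chain from an oxygen on an aromatic ring. The chain keeps its length, and only its double bond is gone. Among the compounds with values here, no pair of measured compounds shows what such a change does in this assay, so any forecast has to start from compound 2 at 32000 nM. A small change at most is expected, probably no larger than the scatter, with a slight lean towards a weaker value. The expected size is a 1.4-fold higher number from compound 2 to compound 4 (0.15 log units; within the scatter), which stays within the usual spread of repeated measurements. For compound 4 the estimated half-maximal inhibitory concentration is 45000 nM, with an expected range from 16000 nM to 100000 nM.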

Compound 4, half-maximal inhibitory concentration: > 100000 nM
Compound 4 gave a limit, no number; the forecaster's own chance of this, stated with the estimate: 20%; at least 2.2-fold (0.34 log units) between middle value and limit.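

In this assay compound 4 gives > 100000 nM, which is a limit of the assay and not a number. Decyl in place of dec-1-en-1-yl, on a saturated chain carbon, eight bonds along the chain from an oxygen on an aromatic ring, gives an at least 3.1-fold higher number from compound 2 to compound 4 (0.49 log units; beyond the scatter), so at this position the loss of the double bond alone, with the chain length kept, is enough to shift the reading beyond the scatter, which the earlier compounds could not show. The step gives only a lower bound on the change, and its full size cannot be read because compound 4 sits at the top of the measurable range: the limit of > 100000 nM in this assay, at which 2 of the 4 values shown sit.

The compounds shown leave open whether the same change would act alike in the arrangement of the core seen in compound 1. They also leave open how a shorter chain, a triple bond in place of the double bond, or a carboxylic acid on the chain would behave at this position in this assay.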